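The source may report more compounds than this note shows. Statements on the series, on what has been measured and on what is new or still open speak of the compounds shown alone.

Compound 1 `Cc1cc(COc2ccccc2F)nc(-c2ccccn2)n1`: 398 nM
Compound 2 `Cc1cc(COc2cccc(F)c2)nc(-c2ccccn2)n1`: 794 nM

In a functional assay on cells for antagonist activity at Free fatty acid receptor 1 (Homo sapiens), read by TR-FRET and inositol phosphate accumulation, with a stated time of 2 h (a lower number here means a stronger inhibitor, a higher number a weaker inhibitor), compound 2 shows the higher of the two numbers, though its distance from compound 1, a 2.0-fold higher number from compound 1 to compound 2 (0.30 log units; within the scatter), lies within the scatter. Compound 3 `COc1cc(COc2cccc(F)c2)nc(-c2ccccn2)n1` differs from compound 2 thus: methoxy in place of methyl on an aromatic carbon. Going by the values given here, the single measured step exchanges one fluorophenyl for another on the oxygen and leaves the shared core untouched, so no measured step bears on methoxy in place of methyl there. Compound 3 is therefore expected close to compound 2, with a step of a 1.0-fold higher number from compound 2 to compound 3 (0.00 log units; within the scatter) and no clear direction, and an estimated value of 800 nM (range 250 nM to 2500 nM).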

Compound 3, half-maximal inhibitory concentration: 1260 nM
Compound 3: the middle estimate sits 1.6-fold (0.20 log units) below what was measured; low and high end bracket the measured number.
By their numbers in this assay, from the lowest: compounds 1, 2 and 3 (each within the scatter of the next, the first and the last beyond it).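

In this assay, methoxy in place of methyl on this aromatic carbon, next to the ring nitrogen, gives a step that stays small (a 1.6-fold higher number from compound 2 to compound 3 (0.20 log units; within the scatter)). Going by these compounds alone, the earlier compounds differed only in the fluorophenyl group, so this is the first sign that the shared core can carry either group here without a step beyond the scatter. Nothing measured accounts for this result.

From the compounds shown here alone, whether an amine or a longer chain such as ethoxy on this carbon would move the number beyond the scatter remains open. So does whether methoxy behaves alike alongside the 2-fluorophenyl group of compound 1.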